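The source may report more compounds than this note shows. Statements on the series, on what has been measured and on what is new or still open speak of the compounds shown alone.

Measured in a functional assay on HT-29 cells (Homo sapiens) for antiproliferative activity, read by sulforhodamine B assay, with a stated time of 48 h; on this read-out higher numbers stand for weaker inhibition and lower numbers for stronger inhibition:
compound 1, `CC(C)c1ccccc1OS(=O)(=O)c1ccc(NC(=O)C(C)(C)C)cc1`, gives 15000 nM;
compound 2, `CC(C)(C)C(=O)Nc1ccc(S(=O)(=O)Oc2ccccc2I)cc1`, gives 9500 nM;
compound 3, `CC(C)c1ccccc1OS(=O)(=O)c1ccc(NC(=O)CCCl)cc1`, gives 16000 nM.

Compound 2 holds the lowest of the three numbers, yet both its neighbours sit within the scatter of it. Compound 4, `O=C(NCCCCl)Nc1ccc(S(=O)(=O)Oc2ccccc2I)cc1`, differs from compound 2 by (3-chloropropyl)amino in place of tert-butyl on a carbonyl carbon. The nearest measured step is the exchange of the acyl group on the same carbonyl carbon, a 1.1-fold higher number from compound 1 to compound 3 (0.03 log units; within the scatter), and the change of the ring substituent, a 1.6-fold lower number from compound 1 to compound 2 (0.20 log units; within the scatter), was also small. On that basis compound 4 is expected to show no step beyond the scatter, a 1.1-fold higher number from compound 2 to compound 4 (0.02 log units; within the scatter). The estimate for compound 4 in this assay is 10000 nM, within a range from 4000 nM to 25000 nM.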

Compound 4, half-maximal inhibitory concentration: 9600 nM
Compound 4: the middle estimate sits 1.0-fold (0.02 log units) above what was measured; measured number inside the range.
By their numbers in this assay, from the lowest: compounds 2, 4, 1 and 3 (each within the scatter of the next).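

In this assay, the earlier compounds had shown only carbon groups on this carbonyl carbon, whereas (3-chloropropyl)amino in place of tert-butyl brings in a nitrogen and a hydrogen-bond donor, with a 1.0-fold higher number from compound 2 to compound 4 (0.00 log units; within the scatter) and thus no step beyond the scatter. This holds for this one exchange with the iodo compounds. Nothing available gives a reason for this result.

The compounds shown leave open whether a longer chain, an amine or a carboxylic acid on this carbonyl carbon would give a step beyond the scatter.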